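The source may report more compounds than this note shows. Statements on the series, on what has been measured and on what is new or still open speak of the compounds shown alone.

Within the data shown here, compound 2 `Cc1ccc(CSc2nc(C(F)(F)F)ccc2CNC(=O)C(C)c2ccc(NS(C)(=O)=O)c(F)c2)cc1` gives 764 nM in an assay on CHO-K1 cells for antagonist activity at transient receptor potential cation channel subfamily V member 1 (Homo sapiens), read by FLIPR (a higher number here means a weaker inhibitor, a lower number a stronger inhibitor), the higher of the two numbers measured so far; compound 1 `CCCCCSc1nc(C(F)(F)F)ccc1CNC(=O)C(C)c1ccc(NS(C)(=O)=O)c(F)c1` gives 95.6 nM in this assay. Among the measured compounds shown here, the single step measured between them, an 8.0-fold higher number from compound 1 to compound 2 (0.90 log units; beyond the scatter), exchanges butyl on a saturated chain carbon bound to a sulfur for 4-methylphenyl. Compound 3 `COc1ccc(CSc2nc(C(F)(F)F)ccc2CNC(=O)C(C)c2ccc(NS(C)(=O)=O)c(F)c2)cc1` differs from compound 2 by methoxy in place of methyl on an aromatic carbon, which read one bond further out is (4-methylbenzyl)sulfanyl to (4-methoxybenzyl)sulfanyl. For the measured compounds named here, no measured step bears on this change: the one step recorded alters the whole group on the chain carbon rather than a substituent of the six-membered aromatic ring it carries, so it gives no direct guide. An exchange of methyl for methoxy on that aromatic carbon is expected to shift this assay by no more than the scatter, in no settled direction. Compound 3 is therefore estimated at 700 nM, within 250 nM to 2000 nM. That estimate corresponds to an expected step of a 1.1-fold lower number from compound 2 to compound 3 (0.04 log units; within the scatter).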

Compound 3, half-maximal inhibitory concentration: 279 nM
Beside the measured number, compound 3's estimate is 2.5-fold (0.40 log units) above it, within the range that was stated.
By their numbers in this assay, from the lowest: compound 1; then compound 3; then compound 2.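

In this assay the aromatic carbon para to a large group proves responsive: methoxy in place of methyl gives a 2.7-fold lower number from compound 2 to compound 3 (0.44 log units; beyond the scatter) and so moves the number beyond the scatter. This recovers only part of what the aromatic group cost, since 4-methoxyphenyl in place of butyl still gives a 2.9-fold higher number from compound 1 to compound 3 (0.47 log units; beyond the scatter) and leaves compound 1 with the lowest number of the three. Nothing available accounts for the shift produced by methoxy.

The compounds shown leave open whether other groups on that same aromatic carbon, such as chlorine, hydroxy or a dimethylamino group, would lower the number further, and whether methoxy would act alike on another carbon of the ring. Also open, going by these compounds, is whether a longer chain in place of butyl would improve on compound 1.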